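This account rests on a few compounds, and the source may have more. Where it says the series, first, only, none or still open, it means among the compounds named here.

Measured in an ADME assay on microsomes from liver (Mus musculus) for metabolic stability, tested at 5 uM; on this read-out higher numbers stand for a longer-lived compound and lower numbers for a shorter-lived compound:
- Compound 1 `CCCCCCCCNc1ccc(C(=O)O)cc1S(=O)(=O)NC`: 0.2 h
- Compound 2 `CNS(=O)(=O)c1cc(C(=O)O)ccc1NCCCCCCCC(F)(F)F`: > 1 h

Compound 2 stands at > 1 h, which is a limit of the assay and not a number. For the measured compounds named here, the one measured step, an at least 5.0-fold higher number from compound 1 to compound 2 (0.69 log units; beyond the scatter), has trifluoromethyl in place of methyl on a saturated chain carbon, and it lies beyond the scatter.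

Compound 3 `O=C(O)c1ccc(NCCCCCCCC(F)(F)F)c(S(=O)(=O)N2CCCC2)c1` keeps that chain and carries pyrrolidin-1-yl in place of methylamino on a sulfonyl sulfur. Going by the values given here, no measured step touches this place, so the size of the change in this assay cannot be read directly from the data. The step of an at least 5.0-fold higher number from compound 1 to compound 2 (0.69 log units; beyond the scatter) bears on it only indirectly, since compound 3 retains the chain change made in that step. On these data alone, no step beyond the scatter is therefore expected, and the direction remains open. The expected step is a number no higher from compound 2 to compound 3 (the limit leaves the size open). Compound 3 is estimated at 1 h, with an expected range from 0.4 h to 2.5 h.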

Compound 3, half-life: > 1 h
Compound 3: only a limit was reported; the forecaster's own chance of this, stated with the estimate: 50%; the middle value lies on the limit itself.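

In this assay compound 3 gives > 1 h, which is a limit of the assay and not a number. No step can be read from compound 2 to compound 3, because both values are limits: the limit of > 1 h in this assay, at which 2 of the 3 values shown sit. The compounds shown leave open whether pyrrolidin-1-yl in place of methylamino on a sulfonyl sulfur changes the half-life at all.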